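The source may hold more compounds than are shown below. What is called first, only, known or untested is meant among the compounds shown, and "the series" means these compounds.

Measured so far:
compound 1 `C=C(C)C(=O)c1ccc(OCc2nc(-c3ccc(C(F)(F)F)cc3)no2)cc1C`, in an assay on HL-60 cells for inhibition of glutathione S-transferase P (Homo sapiens) (on this read-out higher numbers stand for weaker inhibition and lower numbers for stronger inhibition), compound 1 gives 3300 nM
compound 2 `C=C(C)C(=O)c1ccc(OCc2nc(-c3ccccc3)no2)cc1Cl`, in this assay compound 2 gives 600 nM

Compound 2 has the lowest of the two numbers; compound 1, the nearest, sits well beyond the scatter above it. For the measured compounds named here, the two differ in more than one place, so no single step between them can be read off.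

Compound 3 `C=C(C)C(=O)c1ccc(OCc2nc(-c3ccc(C(F)(F)F)cc3)no2)cc1Cl` differs from compound 2 by trifluoromethyl in place of hydrogen on an aromatic carbon. Compound 3 carries the same trifluoromethyl as compound 1, which gives 3300 nM in this assay. A step toward weaker inhibition is expected, moderate in size and with wide uncertainty, since the chloro and methyl differ too. For compound 3 the expected value is 1500 nM, between 500 nM and 4500 nM, which means an expected step of a 2.5-fold higher number from compound 2 to compound 3 (0.40 log units; beyond the scatter).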

Compound 3, half-maximal inhibitory concentration: 700 nM
Compound 3: the middle estimate sits 2.1-fold (0.33 log units) above what was measured; the measured number falls inside the stated range.
By their numbers in this assay, from the lowest: compounds 2 and 3 (each within the scatter of the next); then compound 1.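

In this assay, with chloro on the core, trifluoromethyl in place of hydrogen on this aromatic carbon, para to a large group, leaves the number within the scatter (a 1.2-fold higher number from compound 2 to compound 3 (0.07 log units; within the scatter)). The higher number of compound 1 therefore goes with the other change, chloro in place of methyl on an aromatic carbon (a 4.7-fold lower number from compound 1 to compound 3 (0.67 log units; beyond the scatter)). Nothing available here accounts for either step. From the compounds shown here alone, whether the trifluoromethyl result holds with methyl in place of chloro remains open, as does the outcome with an amine or a carboxylic acid at the para place.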